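A few compounds are considered here, and "the series" means these few. Any claim that something is new, unique, unknown or untested is made for them only; others in the source may bear on it.

Measured so far:
- compound 1 `COC[C@H]1C[C@@](CC(C)C)(C(=O)O)N(C(=O)c2ccc(C(C)(C)C)c(OC)c2)[C@H]1[C@H]1COC(C)(C)O1` — > 120000 nM
- compound 2 `COC[C@H]1C[C@@](CC(C)C)(C(=O)O)N(C(=O)c2ccc(C(C)(C)C)c(OC)c2)[C@H]1C(=O)OC` — > 120000 nM

In an ADME assay on Huh-5-2 cells (Homo sapiens) for cytotoxicity, with a stated time of 3 days (a lower number here means that less compound is tolerated, a higher number that more compound is tolerated), compound 1 gives > 120000 nM, which is a limit of the assay and not a number. In this assay compound 2 gives > 120000 nM, again a limit of the assay rather than a measured number. Within the data shown here, the one change between them, a step that the two limits leave unreadable from compound 1 to compound 2, therefore cannot be read for size or direction. Compound 2 thus stands at the limit of > 120000 nM in this assay, at which 2 of the 2 values shown sit; no measured number places it anywhere else.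

Compound 3 `C=CCOC[C@H]1[C@@H](COC)C[C@@](CC(C)C)(C(=O)O)N1C(=O)c1ccc(C(C)(C)C)c(OC)c1` differs from compound 2 in one place: (allyloxy)methyl in place of methoxycarbonyl on a saturated ring carbon. Among the measured compounds shown here, the only measured step, from compound 1 to compound 2, bears on a different change at that same ring carbon and is itself unreadable, so it offers no size to carry over. With both known values sitting at the limit, the expectation for compound 3 is that it also shows no toxicity readable below that limit, meaning a step of a number no higher from compound 2 to compound 3 (the limit leaves the size open) in this assay that is expected to stay within the scatter. For compound 3 the estimated half-maximal cytotoxic concentration is therefore 120000 nM, with a range from 50000 nM to 300000 nM, most likely again reported only as a limit.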

Compound 3, half-maximal cytotoxic concentration: > 120000 nM
Compound 3 gave a limit, no number (the forecaster's own chance of this, stated with the estimate: 85%); the middle value lies on the limit itself.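

Compound 1, compound 2 and compound 3 all give a limit of the assay rather than a number in this assay, so no step among them can be read for size or direction: the limit of > 120000 nM in this assay, at which 3 of the 3 values shown sit.

The compounds shown leave open whether changing the group on that saturated ring carbon alters the half-maximal cytotoxic concentration at all.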